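The compounds below may be only part of what the source reports. "The series", "measured", "known", "first", "only" and "open" are said of these compounds alone.

Compound 3 `CCCCNC(=O)CC1CCN(c2nc(N)c3cc(OC)c(OC)cc3n2)CC1` gives 1.4 nM in an assay on isolated protein for displacement of a labelled ligand from Adrenergic receptor alpha-1 (Rattus norvegicus); on this read-out lower numbers stand for stronger inhibition and higher numbers for weaker inhibition. Among the three measured compounds, compound 3 carries the highest number, yet the gaps are small: compound 2 `CCN(CC)C(=O)C1CCN(c2nc(N)c3cc(OC)c(OC)cc3n2)CC1` gives 1.11 nM, and compound 1 `COc1cc2nc(N3CCC(C(=O)NCC4CC4)CC3)nc(N)c2cc1OC` gives 0.9 nM, so all three sit within the scatter of one another. Compound 4 `COc1cc2nc(N3CCC(CC(=O)NCC4CC4)CC3)nc(N)c2cc1OC` differs from compound 3 by cyclopropyl in place of propyl on a saturated chain carbon bound to an amide-type nitrogen. For the measured compounds named here, no measured step isolates this exact swap, but the nearest one is the move a 1.6-fold higher number from compound 1 to compound 3 (0.19 log units; within the scatter), which combined a lengthening of the linker with a change from cyclopropylmethyl to butyl on the amide nitrogen and stayed within the scatter. The steps of a 1.2-fold higher number from compound 1 to compound 2 (0.09 log units; within the scatter) and a 1.3-fold higher number from compound 2 to compound 3 (0.10 log units; within the scatter) likewise show that changing the amide substituent in this series has so far not moved this assay beyond the scatter. The expected step from compound 3 to compound 4 is therefore small, a 1.2-fold lower number from compound 3 to compound 4 (0.07 log units; within the scatter), with no clear direction. For compound 4 the estimate is 1.2 nM, expected within 0.5 nM to 3 nM.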

Compound 4, inhibition constant: 1.08 nM
The estimate for compound 4 lay 1.1-fold (0.05 log units) above the measured number; the range from low to high includes it.
By their numbers in this assay, from the lowest: compounds 1, 4, 2 and 3 (each within the scatter of the next).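

In this assay, cyclopropyl in place of propyl on a saturated chain carbon bound to an amide-type nitrogen gives a 1.3-fold lower number from compound 3 to compound 4 (0.11 log units; within the scatter), so at this place a ring and an open chain are not told apart by this read-out. With the cyclopropylmethyl group held constant, ((cyclopropylmethyl)carbamoyl)methyl in place of (cyclopropylmethyl)carbamoyl gives a 1.2-fold higher number from compound 1 to compound 4 (0.08 log units; within the scatter), which reads the linker change alone, a change that earlier came mixed with the swap of the amide substituent. Set against diethylcarbamoyl, the same ((cyclopropylmethyl)carbamoyl)methyl group gives a 1.0-fold lower number from compound 2 to compound 4 (0.01 log units; within the scatter), and nothing measured here explains why these steps stay so small.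

On these data alone, whether phenyl or a terminal amine in place of cyclopropyl would give a step beyond the scatter remains open. As far as these compounds go, a carboxylic acid at the end of the chain is equally open.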